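Truncating the ring-nitrogen substituent of compound 3 to a urea

A few compounds are considered here, and "the series" means these few. Any claim that something is new, unique, unknown or untested is made for them only; others in the source may bear on it.

Measured compounds:
compound 1, `CC(=O)N1CCC(C(=O)N2CC[C@H](C(=O)N(C)Cc3cc(C(F)(F)F)cc(C(F)(F)F)c3)[C@@H](c3ccc(C)cc3)C2)CC1`, 0.18 nM
compound 2, `CC(=O)N1CCC(C(=O)N2CCC(C(=O)N(C)Cc3cc(C(F)(F)F)cc(C(F)(F)F)c3)=C(c3ccccc3)C2)CC1`, 0.17 nM
compound 3, `CC(=O)NCC(=O)N1CC[C@H](C(=O)N(C)Cc2cc(C(F)(F)F)cc(C(F)(F)F)c2)[C@@H](c2ccc(F)cc2C)C1`, 0.043 nM

In an assay on IM-9 cells for displacement of a labelled ligand from Substance-P receptor (Homo sapiens), read by scintillation counting, with a stated time of 30 min (on this read-out lower numbers stand for stronger inhibition and higher numbers for weaker inhibition), compound 3 gives the lowest of the three numbers; the nearest to it is compound 2, and the gap to compound 2 lies beyond the scatter, as does the wider gap to compound 1. Compound 3 therefore stands alone at the strong end of this small set.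

Compound 4 has the structure `Cc1cc(F)ccc1[C@H]1CN(C(N)=O)CC[C@@H]1C(=O)N(C)Cc1cc(C(F)(F)F)cc(C(F)(F)F)c1`. It differs from compound 3 in one place: amino in place of acetamidomethyl on a carbonyl carbon, so that the whole acetamidomethylcarbonyl unit on the ring nitrogen becomes a carbamoyl group. Going by the values given here, no measured pair shows this change directly; compounds 1 and 2 carry a different and larger group at the same ring nitrogen and give similar numbers, which suggests the read-out is not sharply tied to what sits there. A modest weakening is expected from compound 3 to compound 4, a 2.8-fold higher number from compound 3 to compound 4 (0.45 log units; beyond the scatter), likely beyond the scatter but not large. Compound 4 is estimated at 0.12 nM, within 0.04 nM to 0.4 nM.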

Compound 4, half-maximal inhibitory concentration: 0.035 nM
For compound 4 the middle estimate is 3.4-fold (0.54 log units) above the measured one; the measured number lies below the stated range.
By their numbers in this assay, from the lowest: compounds 4 and 3 (each within the scatter of the next); then compounds 2 and 1 (each within the scatter of the next).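

In this assay, the step with amino in place of acetamidomethyl on a carbonyl carbon is a 1.2-fold lower number from compound 3 to compound 4 (0.09 log units; within the scatter). Going by these compounds alone, the position therefore accepts the plain carbamoyl group as readily as the larger (acetamidomethyl)carbonyl group, at least on this core, something the earlier compounds could not show because no two of them differ in one place only. No supporting measurement bears on why the two groups read alike.

The compounds shown leave open how far this tolerance extends, for instance whether a dimethylamino group or a longer chain ending in a carboxylic acid on the same carbonyl carbon would read the same. They also leave open whether the amino group would behave alike on the different cores of compound 1 and compound 2.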